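Moving the hydroxyl group along the alkyne chain

The source may report more compounds than this note shows. Statements on the series, on what has been measured and on what is new or still open speak of the compounds shown alone.

Measured so far:
compound 1 `NC(=O)c1cc(Cl)c2c(Cl)c(C#CCCO)n([C@H]3CCCNC3)c2n1`: 56 nM
compound 2 `CC(O)CC#Cc1c(Cl)c2c(Cl)cc(C(N)=O)nc2n1[C@H]1CCCNC1`: 48 nM

Both values come from a functional assay on KG-1 cells (Homo sapiens) for antiproliferative activity; on this read-out higher numbers stand for an effect only at larger amounts of compound and lower numbers for an effect already at smaller amounts. Of the two measured numbers, compound 1 has the highest, yet the step of a 1.2-fold lower number from compound 1 to compound 2 (0.07 log units; within the scatter) lies within the scatter, so the two compounds cannot be told apart on this read-out.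

Compound 3 `CC(O)C#Cc1c(Cl)c2c(Cl)cc(C(N)=O)nc2n1[C@H]1CCCNC1` has not been measured. Compared with compound 1, (1-hydroxyethyl in place of 2-hydroxyethyl on a triple-bonded carbon). Among the compounds with values here, the only measured step, a 1.2-fold lower number from compound 1 to compound 2 (0.07 log units; within the scatter), also touches the hydroxyl-bearing chain on the triple-bonded carbon and did not move the number beyond the scatter. That hints that this part of the molecule tolerates small changes, although shifting the hydroxyl group is a different alteration than adding a methyl, so some uncertainty remains.

Compound 3 is therefore expected to give about 60 nM in this assay, most likely between 25 nM and 150 nM. The expected step is a 1.1-fold higher number from compound 1 to compound 3 (0.03 log units; within the scatter), that is, no change beyond the scatter.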

Compound 3, half-maximal effective concentration in the KG-1 assay: 147 nM
Estimate against measurement, compound 3: 2.5-fold (0.39 log units) below; low and high end bracket the measured number.
By their numbers in the KG-1 assay, from the lowest: compounds 2 and 1 (each within the scatter of the next); then compound 3.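

Within the data shown here, in the KG-1 assay, moving the hydroxyl group is the first change on this chain to go beyond the scatter: the result is a 2.6-fold higher number from compound 1 to compound 3 (0.42 log units; beyond the scatter) and a 3.1-fold higher number from compound 2 to compound 3 (0.49 log units; beyond the scatter). The chain on the triple-bonded carbon therefore tolerates a added methyl better than this rearrangement of the same atoms, with both steps modest in size. In a physicochemical assay for solubility, measured as thermodynamic solubility, at pH 7.4 (on this read-out higher numbers stand for higher solubility and lower numbers for lower solubility), compound 1 gives 144000 nM and compound 3 gives 206000 nM, and a 1.4-fold higher number from compound 1 to compound 3 (0.16 log units; within the scatter) does not separate the two. No measurement shown here explains the shift in the cell read-out. Still open, as far as these compounds go, is how this chain on the triple-bonded carbon would respond to an amine in place of the hydroxyl group, or to a longer chain carrying the hydroxyl group.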